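This account rests on a few compounds, and the source may have more. Where it says the series, first, only, none or still open, it means among the compounds named here.

Two compounds of the series have numbers in an assay on BT-549 cells for inhibition of Indoleamine 2,3-dioxygenase 1 (Homo sapiens); on this read-out higher numbers stand for weaker inhibition and lower numbers for stronger inhibition. Compound 1 `CC1=C(CC(=O)c2sccc2Br)C(=O)c2ccccc2C1=O` gives 3.42 nM. Compound 2 `COc1ccccc1C(=O)CC(=O)c1ccc(C)cc1O` gives 20600 nM, the higher of the two numbers and far apart from compound 1, well beyond the scatter of this assay. Compound 3 `Cc1ccc(C(=O)CC(=O)c2ccccc2OC(C)C)c(O)c1` has not yet been measured in this assay. Compound 3 differs from compound 2 in one place: isopropyl in place of methyl on an oxygen on an aromatic ring. Among the measured compounds shown here, no measured pair shares this or any other single change, so there is no measured step to lean on; the two measured compounds differ in many places at once and say nothing about this change on its own. The expectation for compound 3 is a step of a 1.0-fold lower number from compound 2 to compound 3 (0.01 log units; within the scatter), no larger than the scatter in either direction, and the estimate stays near the number of compound 2. Compound 3 is accordingly estimated at 20000 nM, within a range from 6000 nM to 65000 nM.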

Compound 3, half-maximal inhibitory concentration: 10800 nM
The estimate for compound 3 lay 1.9-fold (0.27 log units) above the measured number; the range from low to high includes it.
By their numbers in this assay, from the lowest: compound 1; then compounds 3 and 2 (each within the scatter of the next).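

Among the compounds shown here, the first measured single change, isopropyl in place of methyl on an oxygen on an aromatic ring, gives a 1.9-fold lower number from compound 2 to compound 3 (0.28 log units; within the scatter) in this assay. On this read-out, methoxy and isopropoxy cannot be told apart at this position, and the step holds for this one pair only. No available measurement bears on why the number stays within the scatter here.

Still open, going by these compounds, is whether a longer chain on this oxygen, or one ending in an amine or a carboxylic acid, would also stay within the scatter of compound 2. Also open, on these data alone, is whether the change from methoxy to isopropoxy would give a similar step in any other pair of the series.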